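A few compounds are considered here, and "the series" means these few. Any claim that something is new, unique, unknown or untested is made for them only; others in the source may bear on it.

Measured compounds and their values:
Compound 1, `O=C(O)CCC(=O)Nc1nc2ccc(NC(=O)c3c(Cl)cccc3Cl)cc2s1`, in a functional assay on WI-38 VA13 cells (Homo sapiens) for cytotoxicity; on this read-out lower numbers stand for an effect already at smaller amounts and higher numbers for an effect only at larger amounts of compound: > 6.6 ug/mL
Compound 2, `CC(C)OC(=O)Nc1nc2ccc(NC(=O)c3c(Cl)cccc3Cl)cc2s1`, in this assay: 0.0026 ug/mL

The value of compound 1 is a limit of this assay, not a number. Compound 2 therefore holds the only number shown; the one other value is a limit, (the limit of > 6.6 ug/mL in this assay, at which 1 of the 2 values shown sits). Within the data shown here, the single measured step, an at least 2500-fold lower number from compound 1 to compound 2 (3.40 log units; beyond the scatter), changed the group on the carbonyl carbon of the same side chain that is altered again in the compound now at hand.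

Compound 3, `O=C(Nc1nc2ccc(NC(=O)c3c(Cl)cccc3Cl)cc2s1)OCc1ccccc1`, differs from compound 2 in one place: benzyl in place of isopropyl on an oxygen next to a carbonyl group. The measured step from compound 1 to compound 2 exchanged a 2-carboxyethyl group for an isopropoxy group and was large, but its size cannot be fixed because one end is a limit. The present change keeps the oxygen and the carbonyl and swaps only the group on that oxygen, isopropyl for benzyl. Among the measured compounds shown here, no measured pair shows such a swap. Compound 3 is expected to stay close to compound 2, with a step of a 1.5-fold higher number from compound 2 to compound 3 (0.19 log units; within the scatter) in this assay; the estimate for compound 3 is 0.004 ug/mL, ranging from 0.0008 ug/mL to 0.02 ug/mL.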

Compound 3, half-maximal effective concentration: 0.018 ug/mL
For compound 3 the middle estimate is 4.5-fold (0.65 log units) below the measured one; measured number inside the range.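

In this assay, the group on an oxygen next to a carbonyl group counts in its own right: with the oxygen and the carbonyl kept, benzyl in place of isopropyl gives a 6.9-fold higher number from compound 2 to compound 3 (0.84 log units; beyond the scatter). The earlier pair could not show this, as it exchanged 2-carboxyethyl for isopropoxy and so changed more than the group on that oxygen, whereas the new compound also shows that a second group on the oxygen stays far from compound 1, with an at least 360-fold lower number from compound 1 to compound 3 (2.56 log units; beyond the scatter). The value of compound 1 is a limit of this assay, not a number: the limit of > 6.6 ug/mL in this assay, at which 1 of the 3 values shown sits.

Benzyl differs from isopropyl both in carrying a six-membered aromatic ring and in its count of carbon atoms, and this one pair cannot tell which of the two goes with the higher number. A cyclohexylmethyl group or a phenyl group on the same oxygen would help to separate the two, and an amine on a longer chain there would show how far this position tolerates a very different group.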